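A benzyl group on the ring amide nitrogen

This account rests on a few compounds, and the source may have more. Where it says the series, first, only, none or still open, it means among the compounds named here.

Of the compounds shown here, three sharing one core have been measured in an assay on CHO cells for displacement of a labelled ligand from 5-hydroxytryptamine receptor 7 (Homo sapiens); on this read-out higher numbers stand for weaker inhibition and lower numbers for stronger inhibition. Compound 1 `CCC1(CCCCN2CCN(c3ccc(Cl)cc3)CC2)C(=O)Nc2ccccc21` gives 0.38 nM; 0.38 nM (2 entries) in this assay, recorded as two entries rather than one single number. Compound 2 `CCC1(CCCCN2CCN(c3cccc(OC)c3)CC2)C(=O)Nc2ccccc21` gives 2.55 nM in this assay. Within the data shown here, compound 3 `CCC1(CCCCN2CCN(c3ccccc3OC)CC2)C(=O)Nc2ccccc21` gives 5.38 nM in this assay, the highest of the two single numbers; the only step that reaches it is the change from 3-methoxyphenyl to 2-methoxyphenyl on the amine nitrogen in a ring, a 2.1-fold higher number from compound 2 to compound 3 (0.32 log units; beyond the scatter), a modest shift.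

Compound 4 `CCC1(CCCCN2CCN(c3ccccc3OC)CC2)C(=O)N(Cc2ccccc2)c2ccccc21` carries a further change: benzyl in place of hydrogen on an amide-type nitrogen in a ring. Among the measured compounds shown here, no measured pair touches this amide-type nitrogen, so no step among the three compounds bears on it; the only step seen concerns a different ring and is modest. The expectation for compound 4 therefore rests on little, and the step from compound 3 is estimated as a 3.7-fold higher number from compound 3 to compound 4 (0.57 log units; beyond the scatter) in this assay, with a wide spread. Compound 4 is expected to give about 20 nM in this assay, estimated to fall between 3 nM and 150 nM.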

Compound 4, inhibition constant: 6.57 nM
The estimate for compound 4 lay 3.0-fold (0.48 log units) above the measured number; the measured number falls inside the stated range.
By their numbers in this assay, from the lowest: compound 2; then compounds 3 and 4 (each within the scatter of the next).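

Benzyl in place of the amide hydrogen gives a 1.2-fold higher number from compound 3 to compound 4 (0.09 log units; within the scatter) in this assay, so this is the first reading at the amide-type nitrogen, and the change leaves the number where it was. In this one pair, then, the amide hydrogen can give way to a benzyl group, with its six-membered aromatic ring, without a shift beyond the scatter, at least while 2-methoxyphenyl sits on the amine nitrogen in the other ring. No available evidence accounts for this result.

The compounds shown leave open whether benzyl on this nitrogen would read the same alongside the 3-methoxyphenyl group of compound 2 or the aryl group of compound 1. They also do not tell how a methyl group, a longer phenylethyl chain or a chain ending in an amine would read at this position.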